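This account rests on a few compounds, and the source may have more. Where it says the series, first, only, none or still open, it means among the compounds named here.

Measured so far:
- compound 1, `O=C1c2ccccc2C(=O)N1C/C=C\Cn1cc(C#Cc2ccc(Br)cc2)c(=O)[nH]c1=O`: 80000 nM in a functional assay on CCRF-CEM cells (Homo sapiens) for antiproliferative activity, read by MTT assay, with a stated time of 3 days; on this read-out higher numbers stand for weaker inhibition and lower numbers for stronger inhibition
- compound 2, `CCCCCCCCC#Cc1cn(C/C=C/CN2C(=O)c3ccccc3C2=O)c(=O)[nH]c1=O`: > 250000 nM in this assay

For the measured compounds named here, compound 1 is the only compound in this set that gives an actual number in this assay; it stands as a weak inhibitor. Compound 2 reaches only a limit of the assay, (the limit of > 250000 nM in this assay, at which 1 of the 2 values shown sits), so no number is available for it. Going by the values given here, no step between two measured compounds that differ in a single place is available, and the two values together show nothing more than that compound 1 is measurable where compound 2 is not.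

Compound 3, `CCCCc1ccc(C#Cc2cn(C/C=C\CN3C(=O)c4ccccc4C3=O)c(=O)[nH]c2=O)cc1`, is not yet measured. It differs from compound 1 in one place: butyl in place of bromo on an aromatic carbon, para to a large group. Among the compounds with values here, with no comparable step among the measured compounds to draw on, the change from compound 1 to compound 3 is expected to lie within the usual scatter, with the estimated step of a 1.3-fold higher number from compound 1 to compound 3 (0.10 log units; within the scatter). Compound 3 is therefore expected to give about 100000 nM in this assay, within a range of 30000 nM to 250000 nM.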

Compound 3, half-maximal inhibitory concentration: 23000 nM
Beside the measured number, compound 3's estimate is 4.3-fold (0.64 log units) above it; the whole stated range lies above it.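

Exchanging bromo for butyl on this aromatic carbon, para to a large group, gives a 3.5-fold lower number from compound 1 to compound 3 (0.54 log units; beyond the scatter) in this assay. For the compounds shown here, this is the first sign that the read-out responds to what sits at this place on the shared core, and that the larger, all-carbon butyl chain is accepted there with stronger inhibition than bromo gives. The step is modest, however, and compound 3 remains a weak inhibitor at 23000 nM, while nothing measured here accounts for the difference between the two groups.

A single step cannot show whether the number keeps falling as the chain grows, or whether it depends on having a chain at all: a longer chain such as octyl, a shorter one such as ethyl, or an amine or a carboxylic acid at this same place would each be needed to tell, and none of these is among the compounds shown. On these data alone, it also remains open whether the exchange of bromo for butyl would act the same way in a compound with the other arrangement about the double bond of the linker.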